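Swapping the oxazole arm for an aminopyrimidine arm

This account rests on a few compounds, and the source may have more. Where it says the series, first, only, none or still open, it means among the compounds named here.

Measured compounds:
compound 1, `Cc1nc(-c2nn(Cc3ccccc3F)c3ncccc23)oc1CO`: 900 nM
compound 2, `CC(C)S(=O)(=O)c1cnc(-c2nn(Cc3ccccc3F)c3ncccc23)nc1N`: 517000 nM

In a functional assay (aorta) with Oryctolagus cuniculus as the target (a lower number here means a stronger inhibitor, a higher number a weaker inhibitor), compound 1 gives 900 nM, the lowest of the two numbers; in this assay compound 2 gives 517000 nM, a far higher number, beyond the scatter. Compound 3, `Cc1cc(N)nc(-c2nn(Cc3ccccc3F)c3ncccc23)n1`, is not yet measured. It differs from compound 1 in one place: 4-amino-6-methylpyrimidin-2-yl in place of 5-(hydroxymethyl)-4-methyl-1,3-oxazol-2-yl on an aromatic carbon. Both arms carry one hydrogen-bond donor and three acceptors, but the five-membered ring with two hetero atoms is replaced by a six-membered ring with two hetero atoms. For the measured compounds named here, no step between measured compounds exists for this kind of change, so the estimate rests only on compound 1 and on the weak showing of compound 2, which also carries an aminopyrimidine arm. A step toward a higher number is expected, of a 6.7-fold higher number from compound 1 to compound 3 (0.82 log units; beyond the scatter), beyond the scatter. Compound 3 is estimated at 6000 nM, within 900 nM to 40000 nM.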

Compound 3, half-maximal inhibitory concentration: 536000 nM
Compound 3: middle estimate off by 89-fold (1.95 log units), on the low side; the whole stated range lies below it.
By their numbers in this assay, from the lowest: compound 1; then compounds 2 and 3 (each within the scatter of the next).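

In this assay, replacing 5-(hydroxymethyl)-4-methyl-1,3-oxazol-2-yl with 4-amino-6-methylpyrimidin-2-yl on the same aromatic carbon gives a 600-fold higher number from compound 1 to compound 3 (2.77 log units; beyond the scatter), so this position is highly sensitive to which arm it carries. The change is large even though both arms have the same counts of heavy atoms, hydrogen-bond donors and hydrogen-bond acceptors, so those counts alone do not predict the result here. Nothing measured here explains the loss.

These compounds cannot show whether the change of ring, the loss of the hydroxymethyl group or the gain of the amino group matters most, as all of these change together. An oxazole arm carrying a carboxylic acid or an aminomethyl group in place of the hydroxymethyl group would show how much that one substituent contributes.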